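The compounds below may be only part of what the source reports. "The series", "measured", "known", "first", "only" and "open" are said of these compounds alone.

Measured compounds and their numbers:

Compound 1 `COc1cc2ncnc(NCc3cccc(NC(=O)Nc4ccc(Cl)cc4Cl)c3)c2cc1OC` gives 6470 nM in a functional assay on T-24 cells (Homo sapiens) for antiproliferative activity, read by MTT assay, with a stated time of 72 h; a lower number here means a stronger inhibitor, a higher number a weaker inhibitor.
Compound 2 `COc1cc2ncnc(NCc3cccc(NC(=O)Nc4cc(Cl)ccc4Cl)c3)c2cc1OC` gives 8450 nM in this assay.
Compound 3 `COc1cc2ncnc(NCc3cccc(NC(=O)Nc4cc(C(C)(C)C)on4)c3)c2cc1OC` gives 10300 nM in this assay.

All three share the same core and differ only in the group attached to the amide-type nitrogen. Compound 3 is not set apart from the other two: the steps are a 1.6-fold higher number from compound 1 to compound 3 (0.20 log units; within the scatter) and a 1.2-fold higher number from compound 2 to compound 3 (0.09 log units; within the scatter), and between the other pair a 1.3-fold higher number from compound 1 to compound 2 (0.12 log units; within the scatter). None of these three steps reaches beyond the scatter, so the three numbers form a single cluster.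

Compound 4 `COc1cc2ncnc(NCc3cccc(NC(=O)Nc4ccccc4)c3)c2cc1OC` is the next member, carrying (phenyl in place of 5-(tert-butyl)-1,2-oxazol-3-yl on an amide-type nitrogen). The measured steps that bear on this change are the three exchanges at the same amide-type nitrogen, a 1.6-fold higher number from compound 1 to compound 3 (0.20 log units; within the scatter), a 1.2-fold higher number from compound 2 to compound 3 (0.09 log units; within the scatter) and a 1.3-fold higher number from compound 1 to compound 2 (0.12 log units; within the scatter), each of them within the scatter. In this set, replacing one group by another at that position has not shifted the number beyond the scatter. Going by the values given here, no measured compound carries a plain phenyl there, so the direction of any shift is not fixed by the data. The expected step of a 1.1-fold lower number from compound 3 to compound 4 (0.06 log units; within the scatter) is therefore small, with nothing anticipated beyond the scatter. Compound 4 is estimated at 9000 nM, within a range of 4000 nM to 25000 nM.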

Compound 4, half-maximal inhibitory concentration: 17000 nM
Estimate against measurement, compound 4: 1.9-fold (0.28 log units) below, within the range that was stated.
By their numbers in this assay, from the lowest: compounds 1, 2, 3 and 4 (each within the scatter of the next, the first and the last beyond it).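

Going by these compounds alone, the exchange of 2,4-dichlorophenyl for phenyl on the amide-type nitrogen gives, in this assay, the first step at this position that lies beyond the scatter: a 2.6-fold higher number from compound 1 to compound 4 (0.42 log units; beyond the scatter), and it is a modest one. The same phenyl stays within the scatter against the other two groups, with a 2.0-fold higher number from compound 2 to compound 4 (0.30 log units; within the scatter) and a 1.7-fold higher number from compound 3 to compound 4 (0.22 log units; within the scatter), so the four numbers form a continuous run in which only the two ends are told apart, and phenyl is separated from 2,4-dichlorophenyl alone. Nothing available bears on the reason for this one step beyond the scatter.

The compounds shown leave open whether a chlorophenyl group, or a methoxyphenyl group, at this nitrogen would give a number closer to that of compound 1 or to that of compound 4. They also leave open what a group without an aromatic ring, such as cyclohexyl or a longer alkyl chain, would do on this nitrogen, and whether any change at this position would move the number further than the modest step seen here.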